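A few compounds are considered here, and "the series" means these few. Any claim that something is new, unique, unknown or untested is made for them only; others in the source may bear on it.

Compound 1 `Cn1c(=O)c(S(=O)(=O)c2ccc([N+](=O)[O-])cc2F)cc2cnc(Nc3ccc4[nH]ccc4c3)nc21` is the stronger of the two measured compounds: in a functional assay on DU-145 cells (Homo sapiens) for inhibition, read by trypan blue exclusion, with a stated time of 72 h (on this read-out higher numbers stand for weaker inhibition and lower numbers for stronger inhibition), compound 1 gives 400 nM, while compound 2 `Cn1c(=O)c(S(=O)(=O)c2ccc(Cl)cc2)cc2cnc(Nc3cnc4ccccc4c3)nc21` gives 15000 nM, a gap beyond the scatter. Within the data shown here, compound 2 differs from compound 1 in two places, so its values show only that the pair is far apart. Compound 3 `Cn1c(=O)c(S(=O)(=O)c2ccc(Cl)cc2Cl)cc2cnc(Nc3ccc4[nH]ccc4c3)nc21` has not yet been measured; it differs from compound 1 by 2,4-dichlorophenyl in place of 2-fluoro-4-nitrophenyl on a sulfonyl sulfur. Among the measured compounds shown here, no measured pair tells the size of this change. A modest weakening is expected, so the step of a 2.5-fold higher number from compound 1 to compound 3 (0.40 log units; beyond the scatter) is an estimate. Compound 3 is expected to give about 1000 nM, between 250 nM and 4000 nM.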

Compound 3, half-maximal inhibitory concentration: 1000 nM
For compound 3 middle estimate and measured number coincide at the digits printed, within the range that was stated.
By their numbers in this assay, from the lowest: compound 1; then compound 3; then compound 2.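

With the rest of compound 1 kept, a change on a sulfonyl sulfur can now be read on its own: in this assay, 2,4-dichlorophenyl in place of 2-fluoro-4-nitrophenyl gives a 2.5-fold higher number from compound 1 to compound 3 (0.40 log units; beyond the scatter). The change weakens inhibition modestly but leaves compound 3 well short of the number of compound 2. No measurement at hand offers an explanation for this step.

Going by these compounds, both ring substituents change at once, so the share of each in the step stays open. So does the effect of an amine or a carboxylic acid on the aryl group at this sulfonyl sulfur.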